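The source may report more compounds than this note shows. Statements on the series, on what has been measured and on what is new or still open speak of the compounds shown alone.

Measured in a functional assay on MCF7 cells (Homo sapiens) for inhibition, read by MTT assay, with a stated time of 72 h; on this read-out lower numbers stand for stronger inhibition and higher numbers for weaker inhibition:
compound 1 `C=CC(=O)Nc1cccc(Oc2nc(Nc3cccc(OC)c3)nc3ccsc23)c1` gives 19000 nM
compound 2 `COc1cccc(Nc2nc(Oc3cccc(NC(=O)C=C(C)C)c3)c3sccc3n2)c1` gives 35800 nM
compound 3 `COc1cccc(Nc2nc(Oc3cccc(NC(=O)/C=C/C(C)C)c3)c3sccc3n2)c1` gives 43900 nM

Compound 1 holds the lowest number of the three: its gap to compound 2, a 1.9-fold higher number from compound 1 to compound 2 (0.28 log units; within the scatter), lies within the scatter, while its gap to compound 3, a 2.3-fold higher number from compound 1 to compound 3 (0.36 log units; beyond the scatter), is a modest step beyond it. Compound 4 `C=CC(=O)Nc1cccc(Oc2nc(Nc3cccc(C#N)c3)nc3ccsc23)c1` differs from compound 1 by cyano in place of methoxy on an aromatic carbon. Every measured step, including a 1.2-fold higher number from compound 2 to compound 3 (0.09 log units; within the scatter), alters only the group on a carbonyl carbon; none touches the methoxy, so nothing measured bears directly on this change. The expectation for compound 4 is therefore no step beyond the scatter, no change at the digits printed from compound 1 to compound 4 (within the scatter), with a wide range. Estimated value for compound 4: 19000 nM (range 6000 nM to 60000 nM).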

Compound 4, half-maximal inhibitory concentration: 19000 nM
Compound 4: middle estimate and measured number agree at the digits printed; the measured number falls inside the stated range.
By their numbers in this assay, from the lowest: compounds 1, 4, 2 and 3 (each within the scatter of the next, the first and the last beyond it).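

Among these compounds, the earlier compounds varied only the group on a carbonyl carbon, so compound 4 gives the first reading at the other end of the molecule: in this assay, going from 3-methoxyphenyl to 3-cyanophenyl gives (no change at the digits printed from compound 1 to compound 4 (within the scatter)). At this place on the ring, cyano and methoxy therefore cannot be told apart on this read-out.

On these data alone, whether an amine, a carboxylic acid or a longer chain here would read the same stays open, as does whether cyano behaves alike with the 2-methylprop-1-en-1-yl group of compound 2 on the carbonyl carbon. Nothing available accounts for the two groups reading alike.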